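This account rests on a few compounds, and the source may have more. Where it says the series, first, only, none or still open, it means among the compounds named here.

Measured compounds in a functional assay on HeLa cells (Homo sapiens) for inhibition, read by MTT assay, with a stated time of 48 h; a lower number here means a stronger inhibitor, a higher number a weaker inhibitor:
compound 1 `COc1ccc2c(=O)c(/C=C/C(=O)Nc3ccc(C)cc3)coc2c1`: 24100 nM
compound 2 `COc1ccc2c(=O)c(/C=C/C(=O)Nc3ccc(Cl)cc3)coc2c1`: > 100000 nM, a limit of the assay
compound 3 `COc1ccc2c(=O)c(/C=C/C(=O)NCc3ccccc3F)coc2c1`: > 100000 nM, a limit of the assay

Among the compounds with values here, compound 1 is the only member of the series with an actual number in this assay; the other two values are limits, as the limit of > 100000 nM in this assay, at which 2 of the 3 values shown sit, records. Both measured steps move away from compound 1 towards weaker inhibition: an at least 4.1-fold higher number from compound 1 to compound 2 (0.61 log units; beyond the scatter) and an at least 4.1-fold higher number from compound 1 to compound 3 (0.61 log units; beyond the scatter). The step from compound 2 to compound 3, a step that the two limits leave unreadable from compound 2 to compound 3, cannot be read from the two limits.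

The next compound, compound 4 `COc1ccc2c(=O)c(/C=C/C(=O)Nc3ccccc3OC)coc2c1`, differs from compound 1 by 2-methoxyphenyl in place of 4-methylphenyl on an amide-type nitrogen. Neither measured step touches this exact change, but both show that altering the group on the amide-type nitrogen of compound 1 has so far given weaker inhibition, each time beyond the scatter. The two steps bearing on it, an at least 4.1-fold higher number from compound 1 to compound 2 (0.61 log units; beyond the scatter) and an at least 4.1-fold higher number from compound 1 to compound 3 (0.61 log units; beyond the scatter), therefore point to a weaker number for compound 4 in this assay, with a real chance that only a limit is reported. The estimated step is a 2.5-fold higher number from compound 1 to compound 4 (0.40 log units; beyond the scatter). For compound 4 the expected value in this assay is 60000 nM, with a range from 15000 nM to 150000 nM.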

Compound 4, half-maximal inhibitory concentration: > 100000 nM
Compound 4: only a limit was reported; the forecaster's own chance of this, stated with the estimate: 50%; middle value at least 1.6-fold (0.22 log units) away from the limit.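

The replacement of 4-methylphenyl by 2-methoxyphenyl on the amide-type nitrogen gives an at least 4.1-fold higher number from compound 1 to compound 4 (0.61 log units; beyond the scatter), so an oxygen-bearing aryl group now joins the chloro and 2-fluorobenzyl changes, and no change shown at this place goes against the loss seen from compound 1. In this assay compound 4 gives > 100000 nM, which is a limit of the assay and not a number. Compound 1 therefore remains the only compound with a number in this series, and the values now cluster at one limit: the limit of > 100000 nM in this assay, at which 3 of the 4 values shown sit.

The steps among compound 2, compound 3 and compound 4 cannot be read, so no order among these three can be stated, and the size of each loss from compound 1 has only a lower bound. As far as these compounds go, the change to compound 4 alters both the substituent and where it is named on the phenyl ring, so the effect of either alone stays open, and a 4-methoxyphenyl group on the amide-type nitrogen would be the direct comparison with compound 1 in this assay.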